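From compound 1 to compound 4: a cytotoxicity outlook

The source may hold more compounds than are shown below. What is called first, only, known or untested is meant among the compounds shown, and "the series" means these compounds.

Compound 1 `COCC(=O)OCCc1c(-c2ccccc2Cl)c2cc(Cl)ccc2[nH]c1=O` was tested in an ADME assay on HepG2 2.2.15 cells (Homo sapiens) for cytotoxicity (a lower number here means that less compound is tolerated, a higher number that more compound is tolerated), where compound 1 gives 74000 nM. Two relatives differ from it only at the carbonyl carbon: compound 2 `O=C(OCCc1c(-c2ccccc2Cl)c2cc(Cl)ccc2[nH]c1=O)C1CCCC1` gives 46000 nM and compound 3 `O=C(CCOc1ccccc1)OCCc1c(-c2ccccc2Cl)c2cc(Cl)ccc2[nH]c1=O` gives 46000 nM. The steps are a 1.6-fold lower number from compound 1 to compound 2 (0.21 log units; within the scatter) and a 1.6-fold lower number from compound 1 to compound 3 (0.21 log units; within the scatter), and between the two relatives no change at the digits printed from compound 2 to compound 3 (within the scatter); compound 1 thus stands level with both within the scatter. Compound 4 `COc1ccc(/C=C/C(=O)OCCc2c(-c3ccccc3Cl)c3cc(Cl)ccc3[nH]c2=O)cc1` carries a change at the same place: 2-(4-methoxyphenyl)ethenyl in place of methoxymethyl on a carbonyl carbon. Since the earlier exchanges there, a 1.6-fold lower number from compound 1 to compound 2 (0.21 log units; within the scatter) and a 1.6-fold lower number from compound 1 to compound 3 (0.21 log units; within the scatter), stayed within the scatter, a step of a 1.5-fold lower number from compound 1 to compound 4 (0.17 log units; within the scatter) is expected, with no change beyond the scatter. Compound 4 is therefore estimated at 50000 nM, in the range 20000 nM to 120000 nM.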

Compound 4, half-maximal cytotoxic concentration: > 1200000 nM
Compound 4 ended at the assay's limit; the forecaster's own chance of this, stated with the estimate: 10%; middle value at least 24-fold (1.38 log units) from the limit.
By their numbers in this assay, from the lowest: compounds 2, 3 and 1 (each within the scatter of the next). At a limit, above all of these: compound 4.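

In this assay the exchange at this carbonyl carbon now reaches beyond the scatter, with an at least 16-fold higher number from compound 1 to compound 4 (1.20 log units; beyond the scatter) and an at least 26-fold higher number from compound 2 to compound 4 (1.41 log units; beyond the scatter) and an at least 26-fold higher number from compound 3 to compound 4 (1.41 log units; beyond the scatter). The position therefore does respond to what it carries, although methoxymethyl, cyclopentyl and 2-phenoxyethyl stayed within the scatter of each other. The value of compound 4 is a limit of the assay, not a number: the limit of > 1200000 nM in this assay, at which 1 of the 4 values shown sits. The compounds shown leave open whether the double bond or the methoxy group goes with this step. A saturated 2-(4-methoxyphenyl)ethyl group or a plain 2-phenylethenyl group could separate the two.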